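Three ethers and an unsubstituted analogue: working notes

A few compounds are considered here, and "the series" means these few. Any claim that something is new, unique, unknown or untested is made for them only; others in the source may bear on it.

Compound 1 `O=C1NCc2c1c1c(c3c2c2ccccc2n3CCO)CCc2cc(OCC3CC3)ccc2-1`: 30%
Compound 2 `O=C1NCc2c1c1c(c3c2c2ccccc2n3CCO)CCc2cc(OCc3ccccn3)ccc2-1`: 36%
Compound 3 `O=C1NCc2c1c1c(c3c2c2ccccc2n3CCO)CCc2ccccc2-1`: 14%

In an assay on isolated protein for inhibition of mitogen-activated protein kinase kinase kinase 9 (Homo sapiens), tested at 1 uM (on this read-out lower numbers stand for less inhibition and higher numbers for more inhibition at the one concentration tested (going by the name of the read-out)), compound 3 stands lowest of the three numbers. The steps of a number 16 percentage points lower from compound 1 to compound 3 (beyond the scatter) and a number 22 percentage points lower from compound 2 to compound 3 (beyond the scatter) are both beyond the scatter, whereas a number 6 percentage points higher from compound 1 to compound 2 (within the scatter) stays within it. Compound 4 `N#CCCCOc1ccc2c(c1)CCc1c-2c2c(c3c4ccccc4n(CCO)c13)CNC2=O` differs from compound 3 by 3-cyanopropoxy in place of hydrogen on an aromatic carbon. The two steps into compound 3 bear on this change: each removed an ether group at the same place and lowered the read-out modestly. The entering group has no ring, unlike the cyclopropylmethoxy and (pyridin-2-yl)methoxy groups, so the gain is expected but with some uncertainty. A modest upward step a number 14 percentage points higher from compound 3 to compound 4 (beyond the scatter) is estimated. Compound 4 is expected to give 28%, between 14% and 42%.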

Compound 4, a percentage reported as inhibition, at one concentration (the size of the read-out at that concentration, not a potency): 58%
Beside the measured number, compound 4's estimate is 30 percentage points below it; measured number outside the range, above it.
By their numbers in this assay, from the lowest: compound 3; then compounds 1 and 2 (each within the scatter of the next); then compound 4.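

In this assay, an ether at this position need carry no ring: 3-cyanopropoxy on the aromatic carbon gives a number 44 percentage points higher from compound 3 to compound 4 (beyond the scatter). The outer part of the ether also counts here, unlike the change between compound 1 and compound 2, with a number 28 percentage points higher from compound 1 to compound 4 (beyond the scatter) and a number 22 percentage points higher from compound 2 to compound 4 (beyond the scatter). Nothing available explains this gain.

On these data alone, whether the gain belongs to the nitrile or to the chain itself stays open. A plain butoxy group, or an ether chain ending in an amine or a carboxylic acid, would bear on that question.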